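The source may hold more compounds than are shown below. What is called first, only, known or untested is meant among the compounds shown, and "the series" means these compounds.

Measured so far:
- compound 1 `CC(=O)Nc1ccc(CN2CCN(CCCc3c[nH]c4ccc(-n5cnnc5)cc34)CC2)cc1`: 2.5 nM
- compound 2 `CN1CCN(CCCCc2c[nH]c3ccc(-n4cnnc4)cc23)CC1`: 210 nM

In an assay on CHO cells for displacement of a labelled ligand from 5-hydroxytryptamine receptor 1D (Homo sapiens) (on this read-out higher numbers stand for weaker inhibition and lower numbers for stronger inhibition), compound 1 gives 2.5 nM and stands as the lowest of the two numbers. Compound 2 differs from compound 1 in several places. In this assay compound 2 gives 210 nM; the gap between the two values lies beyond the scatter, with compound 1 holding the lower number.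

Compound 3 `c1ccc(N2CCN(CCCc3c[nH]c4ccc(-n5cnnc5)cc34)CC2)cc1` has not yet been measured. It differs from compound 1 by phenyl in place of 4-acetamidobenzyl on an amine nitrogen in a ring. Within the data shown here, no comparable step between measured compounds exists, so the expected size of this step rests on the two values alone. Since compound 2, which carries a small group on the same ring nitrogen, gives 210 nM in this assay, a rise in the number is expected, though a smaller one than that gap.

The step from compound 1 to compound 3 is expected to be a 12-fold higher number from compound 1 to compound 3 (1.08 log units; beyond the scatter). Compound 3 is estimated at 30 nM in this assay, with a range from 5 nM to 200 nM.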

Compound 3, half-maximal inhibitory concentration: 1.4 nM
Beside the measured number, compound 3's estimate is 21-fold (1.33 log units) above it; the measured number lies below the stated range.
By their numbers in this assay, from the lowest: compounds 3 and 1 (each within the scatter of the next); then compound 2.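

Replacing 4-acetamidobenzyl with phenyl on the amine nitrogen in the ring gives, in this assay, a 1.8-fold lower number from compound 1 to compound 3 (0.25 log units; within the scatter). The two groups are therefore not told apart at this position: the hydrogen-bond donor and acceptor counted on 4-acetamidobenzyl are absent from phenyl, yet the read-out stays within the scatter, so neither is required here for a low number on the shared core. No measured evidence bears on why the two groups read alike.

Open, going by these compounds, is whether an unsubstituted benzyl or a pyridyl on this nitrogen would also stay within the scatter of these two compounds. Also open, on these data alone, is how far a small group such as methyl on this nitrogen would move the number with the rest of compound 1 held unchanged.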